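Weak Inhibition Across Closely Related Nucleoside Analogues

The source may hold more compounds than are shown below. What is called first, only, known or untested is meant among the compounds shown, and "the series" means these compounds.

Three compounds sharing one core were tested in an ADME assay on MRC5 cells (Homo sapiens), read by MTT assay, with a stated time of 72 h; on this read-out higher numbers stand for weaker inhibition and lower numbers for stronger inhibition. Compound 1 `C#Cc1cn([C@@H]2O[C@H](CO)[C@@H](O)[C@H]2O)c2ncnc(N(C)C)c12` gives 36100 nM in this assay. Compound 2 `C#Cc1cn([C@@H]2O[C@H](CO)[C@@H](O)[C@H]2O)c2ncnc(NC)c12` reaches only a limit of the assay, > 100000 nM, in this assay. Within the data shown here, the only measured step between two compounds is an at least 2.7-fold higher number from compound 1 to compound 2 (0.44 log units; beyond the scatter). Compound 3 `C#Cc1cn([C@@H]2O[C@H](CO)[C@@H](O)[C@H]2O)c2nc(N)nc(OC)c12` also shows only a limit, > 100000 nM, in this assay, so it stands at the limit of > 100000 nM in this assay, at which 2 of the 3 values shown sit, and cannot be placed more precisely among the numbers. Compound 4 `C#Cc1cn([C@@H]2O[C@H](CO)[C@@H](O)[C@H]2O)c2ncnc(OC)c12` differs from compound 3 in one place: hydrogen in place of amino on an aromatic carbon. Among the measured compounds shown here, no measured step covers this change; the step from compound 1 to compound 2 concerned a methyl on a nitrogen, not an amino on an aromatic carbon, so it offers no direct guide. Because compound 3 already sits at the limit of > 100000 nM in this assay, at which 2 of the 3 values shown sit, the direction of any change cannot be read from its number. Compound 4 is expected to remain weak, estimated at 150000 nM (range 50000 nM to 500000 nM), and will most likely again be reported only as a limit. That estimate corresponds to an expected step that the limit leaves unreadable from compound 3 to compound 4.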

Compound 4, half-maximal inhibitory concentration: > 100000 nM
Compound 4 was reported as a limit; the forecaster's own chance of this, stated with the estimate: 80%; the middle value is on the limit's open side.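

In this assay compound 4 gives > 100000 nM, which is a limit of the assay and not a number. Methoxy in place of dimethylamino on this aromatic carbon gives an at least 2.7-fold higher number from compound 1 to compound 4 (0.44 log units; beyond the scatter), so a second replacement of dimethylamino, after methylamino in compound 2, also ends at the limit, while the steps to compound 4 from compound 2 and from compound 3 join limit to limit and cannot be read. Removing the amino group from compound 3 therefore brings no readable gain, and compound 1 remains the only compound with a measured number: the limit of > 100000 nM in this assay, at which 3 of the 4 values shown sit.

Going by these compounds, how far compound 2, compound 3 and compound 4 lie past the limit stays unknown, and so does any order among them. On these data alone, whether diethylamino on the same aromatic carbon would give a lower number than compound 1 also remains open.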